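Cyclohexyloxy for Phenyl on a Benzoylguanidine Sulfone

A few compounds are considered here, and "the series" means these few. Any claim that something is new, unique, unknown or untested is made for them only; others in the source may bear on it.

Measured compounds:
compound 1 `CCc1cc(Br)c(S(C)(=O)=O)cc1C(=O)N=C(N)N` gives 41 nM
compound 2 `CS(=O)(=O)c1cc(C(=O)N=C(N)N)c(Cl)cc1Cl` gives 140 nM
compound 3 `Cc1cc(-c2ccccc2)c(S(C)(=O)=O)cc1C(=O)N=C(N)N` gives 19 nM

Of the compounds shown here, three have been measured in a functional assay for inhibition of sodium/hydrogen exchanger (Oryctolagus cuniculus); on this read-out higher numbers stand for weaker inhibition and lower numbers for stronger inhibition. Compound 3 gives 19 nM in this assay, the lowest of the three numbers. Its nearest neighbour is compound 1, whose number is higher by a margin beyond the scatter, and compound 2 lies furthest away, also beyond the scatter. Going by the values given here, no two measured compounds differ in only one place, so no single step between measured compounds can be read off.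

Compound 4 `Cc1cc(OC2CCCCC2)c(S(C)(=O)=O)cc1C(=O)N=C(N)N` has not yet been measured. It differs from compound 3 as follows: cyclohexyloxy in place of phenyl on an aromatic carbon. The shared core and the methylsulfonyl and methyl groups stay as they are.

Among the compounds with values here, since no measured pair shows what exchanging a phenyl for a cyclohexyloxy does in this assay, the expectation rests on compound 3 alone. The step of a 1.6-fold higher number from compound 3 to compound 4 (0.20 log units; within the scatter) is expected to be small, within or only just beyond the scatter, and if anything towards a somewhat higher number. Compound 4 is therefore estimated to give 30 nM in this assay, with a range from 10 nM to 90 nM.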

Compound 4, half-maximal inhibitory concentration: 37 nM
Estimate against measurement, compound 4: 1.2-fold (0.09 log units) below; low and high end bracket the measured number.
By their numbers in this assay, from the lowest: compounds 3, 4 and 1 (each within the scatter of the next, the first and the last beyond it); then compound 2.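

Going by these compounds alone, compound 3 and compound 4 form the first pair here that differs in one place, and in this assay the exchange of phenyl for cyclohexyloxy comes with a 1.9-fold higher number from compound 3 to compound 4 (0.29 log units; within the scatter) at this aromatic carbon, ortho to a methylsulfonyl group and meta to a methyl group. The assay therefore does not separate these two groups at this position, although one is a six-membered aromatic ring joined directly to the core and the other is a six-membered non-aromatic ring that enters with an oxygen and one hydrogen-bond acceptor, so this position is shown to accept either group without a change that exceeds the scatter. Nothing available explains this outcome or links it to any property of either group.

The compounds shown leave open whether the ring or the oxygen counts for more at this position, a question that phenoxy and cyclohexyl would each address from one side. They also leave open how far the position accepts groups of a different kind, such as an amine or a carboxylic acid.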